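Methyl to Trifluoromethyl: What to Expect for Compound 4

This account rests on a few compounds, and the source may have more. Where it says the series, first, only, none or still open, it means among the compounds named here.

Compound 3 `Cc1ccc(S(=O)(=O)/N=C(/CCNC2=CC(=O)c3ccccc3C2=O)Nc2cccc(C)c2)cc1` gives 10200 nM in a functional assay on DU-145 cells (Homo sapiens) for cytotoxicity, read by MTT assay, with a stated time of 48 h (a higher number here means a weaker inhibitor, a lower number a stronger inhibitor), and stands at the low end of the three numbers recorded. Compound 2 `Cc1ccc(S(=O)(=O)/N=C(/CCNC2=CC(=O)c3ccccc3C2=O)Nc2ccccc2I)cc1` gives 11700 nM. a 1.1-fold lower number from compound 2 to compound 3 (0.06 log units; within the scatter), so these two cannot be told apart. Compound 1 `Cc1ccc(S(=O)(=O)/N=C(/CCNC2=CC(=O)c3ccccc3C2=O)Nc2ccc(Cl)cc2)cc1` gives 32400 nM. a 3.2-fold lower number from compound 1 to compound 3 (0.50 log units; beyond the scatter), and a 2.8-fold lower number from compound 1 to compound 2 (0.44 log units; beyond the scatter). Compound 4 `Cc1ccc(S(=O)(=O)/N=C(/CCNC2=CC(=O)c3ccccc3C2=O)Nc2cccc(C(F)(F)F)c2)cc1` carries the change (trifluoromethyl in place of methyl on an aromatic carbon), trifluoromethyl in place of methyl on an aromatic carbon. Going by the values given here, no measured step exchanges these two groups; the steps from compound 1 show only that altering the substituent on the (3-methylphenyl)amino part moves the number by a modest amount. A step within the scatter, or at most modest and of unclear direction, is therefore expected. Compound 4 is estimated at 10000 nM, between 4000 nM and 25000 nM, so a 1.0-fold lower number from compound 3 to compound 4 (0.01 log units; within the scatter) is expected.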

Compound 4, half-maximal inhibitory concentration: 84100 nM
Compound 4: middle estimate off by 8.4-fold (0.92 log units), on the low side; the whole stated range lies below it.
By their numbers in this assay, from the lowest: compounds 3 and 2 (each within the scatter of the next); then compound 1; then compound 4.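

In this assay the exchange of methyl for trifluoromethyl at this position is far from neutral, giving an 8.2-fold higher number from compound 3 to compound 4 (0.92 log units; beyond the scatter) and extending the series upward: a 7.2-fold higher number from compound 2 to compound 4 (0.86 log units; beyond the scatter) and a 2.6-fold higher number from compound 1 to compound 4 (0.41 log units; beyond the scatter) place compound 4 beyond the scatter of every other compound. Going by these compounds alone, the earlier steps ran only downward from compound 1, so this is the first sign that a change on the (3-methylphenyl)amino part can raise the number past that of compound 1. Nothing available gives a reason for this step. From the compounds shown here alone, what a chlorine, a methoxy group or an amine would do in the same place stays open.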